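This account rests on a few compounds, and the source may have more. Where it says the series, first, only, none or still open, it means among the compounds named here.

Going by the values given here, the three compounds measured so far share one core and differ only in the aryl group on an amide-type nitrogen. In a functional assay on CRL2813 cells (Homo sapiens) for cytotoxicity, read by sulforhodamine B assay, with a stated time of 5 days (on this read-out higher numbers stand for weaker inhibition and lower numbers for stronger inhibition), compound 1 `O=C(Nc1ccc(Cl)cc1)N[C@H]1CC[C@H](Oc2ccc(F)cc2)CC1` gives only a limit, > 20000 nM. Compound 2 `COc1cccc(NC(=O)N[C@H]2CC[C@H](Oc3ccc(F)cc3)CC2)c1` gives 14000 nM in this assay. Compound 3 `Cc1ccccc1NC(=O)N[C@H]1CC[C@H](Oc2ccc(F)cc2)CC1`, the starting point of the step followed here, also reaches only a limit, > 20000 nM, so its place is known only as the limit of > 20000 nM in this assay, at which 2 of the 3 values shown sit. Compound 3 thus stands at the upper end of the numbers shown; the one readable step to it is an at least 1.4-fold higher number from compound 2 to compound 3 (0.15 log units; that floor lies within the scatter), while a step that the two limits leave unreadable from compound 1 to compound 3 and an at least 1.4-fold lower number from compound 1 to compound 2 (0.15 log units; that floor lies within the scatter) add little. Compound 4 `CSc1cccc(NC(=O)N[C@H]2CC[C@H](Oc3ccc(F)cc3)CC2)c1` differs from compound 3 by 3-(methylsulfanyl)phenyl in place of 2-methylphenyl on an amide-type nitrogen. The closest measured analogue is compound 2, whose 3-methoxyphenyl group sits on the same amide-type nitrogen; the step from compound 2 to compound 3 went upward, so the change in the other direction is read as a modest gain at best. Compound 4 is therefore expected to give about 12000 nM, within 4000 nM to 30000 nM, a step of an at least 1.6-fold lower number from compound 3 to compound 4 (0.22 log units; that floor lies within the scatter) that is expected to be modest.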

Compound 4, half-maximal inhibitory concentration: 11100 nM
Estimate against measurement, compound 4: 1.1-fold (0.03 log units) above; the measured number falls inside the stated range.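

In this assay, going by these compounds alone, methylsulfanyl in place of methoxy on an aromatic carbon is the first exchange with a number at both ends, and it gives a 1.3-fold lower number from compound 2 to compound 4 (0.10 log units; within the scatter), so the two groups cannot be told apart here. Against the other two aryl groups the steps are an at least 1.8-fold lower number from compound 3 to compound 4 (0.25 log units; that floor lies within the scatter) and an at least 1.8-fold lower number from compound 1 to compound 4 (0.25 log units; that floor lies within the scatter), so their true size remains unknown. Only the 3-methoxyphenyl and 3-(methylsulfanyl)phenyl groups give numbers so far, while compound 1 and compound 3 each remain a limit and not a number: the limit of > 20000 nM in this assay, at which 2 of the 4 values shown sit.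

The compounds shown leave open whether any aryl change can move the number beyond the scatter. They also do not tell how an amine or a carboxylic acid on that aryl ring, or a longer chain on the sulfur, would read.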